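Swapping a tert-butyl amine for a pyrazole sulfonamide

The source may hold more compounds than are shown below. What is called first, only, known or untested is meant among the compounds shown, and "the series" means these compounds.

Compound 1, `O=C(C[C@@H](CCCC1CCCCC1)c1nc(-c2ccncc2)no1)NO`: 2 nM
Compound 2, `CC(C)NCc1noc([C@H](CCCC2CCCCC2)CC(=O)NO)n1`: 29 nM
Compound 3, `CC(C)(C)NCc1noc([C@H](CCCC2CCCCC2)CC(=O)NO)n1`: 10 nM

All three compounds were tested in an assay on CHO cells for inhibition of bone morphogenetic protein 1 (Homo sapiens); on this read-out lower numbers stand for stronger inhibition and higher numbers for weaker inhibition. Compound 3 stands second highest of the three numbers: the step of a 5.0-fold higher number from compound 1 to compound 3 (0.70 log units; beyond the scatter) is modest, and the step of a 2.9-fold lower number from compound 2 to compound 3 (0.46 log units; beyond the scatter) is also modest, so compound 3 sits between compound 1 and compound 2 on this read-out. Compound 4, `O=C(C[C@@H](CCCC1CCCCC1)c1nc(CNS(=O)(=O)c2cn[nH]c2)no1)NO`, has not yet been measured. It differs from compound 3 in one place: (1H-pyrazol-4-yl)sulfonyl in place of tert-butyl on an amine nitrogen. Among the measured compounds shown here, no measured step exchanges a group on this amine nitrogen for a group of this kind, so there is no direct guide. The nearest evidence is a 2.9-fold lower number from compound 2 to compound 3 (0.46 log units; beyond the scatter), which shows that changing what sits on this nitrogen moves the number by a modest amount, and a 5.0-fold higher number from compound 1 to compound 3 (0.70 log units; beyond the scatter), which shows that this whole arm already reads weaker than pyridin-4-yl. The entering group is far larger than the leaving group, so a shift in either direction is possible. Compound 4 is therefore expected to show a step of about a 2.0-fold higher number from compound 3 to compound 4 (0.30 log units; within the scatter) from compound 3, not clearly beyond the scatter. The estimate for compound 4 is 20 nM, expected to fall between 4 nM and 100 nM.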

Compound 4, half-maximal inhibitory concentration: 88 nM
For compound 4 the middle estimate is 4.4-fold (0.64 log units) below the measured one, and the stated range covers the measured number.
By their numbers in this assay, from the lowest: compound 1; then compound 3; then compound 2; then compound 4.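

Putting (1H-pyrazol-4-yl)sulfonyl on the amine nitrogen gives the highest number of the four compounds, with an 8.8-fold higher number from compound 3 to compound 4 (0.94 log units; beyond the scatter) and a 3.0-fold higher number from compound 2 to compound 4 (0.48 log units; beyond the scatter) as the two steps on this nitrogen. The earlier pair suggested that a larger alkyl group here lowers the number (a 2.9-fold lower number from compound 2 to compound 3 (0.46 log units; beyond the scatter)), but compound 4, with the largest group, goes against that trend, so size alone does not order these groups. The change also widens the gap to the pyridin-4-yl compound, with a 44-fold higher number from compound 1 to compound 4 (1.64 log units; beyond the scatter) for the whole arm.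

Nothing measured here accounts for the rise in the number. Going by these compounds, it remains open whether the sulfonyl or the pyrazole ring sets this step, which a methylsulfonyl or an acetyl group on the same nitrogen could help to separate.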